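Fluorine placement and cell toxicity across four analogues

A few compounds are considered here, and "the series" means these few. Any claim that something is new, unique, unknown or untested is made for them only; others in the source may bear on it.

In an ADME assay on HEK293 cells (Homo sapiens) for cytotoxicity, with a stated time of 72 h (on this read-out lower numbers stand for an effect already at smaller amounts and higher numbers for an effect only at larger amounts of compound), compound 2 `Cc1cc(NC(=O)Nc2ccc(F)cc2)c2ccccc2n1` gives > 25000 nM, a limit of the measurement rather than a number. Compound 1 `Cc1cc(NC(=O)Nc2ccc(F)c(F)c2)c2ccccc2n1` gives > 25000 nM, likewise a limit. Compound 3 `Cc1cc(NC(=O)Nc2ccccc2F)c2ccccc2n1` gives > 25000 nM, also a limit. Compound 1 arises from compound 2 by fluoro in place of hydrogen on an aromatic carbon; the step is a step that the two limits leave unreadable from compound 2 to compound 1. The cores of compound 2 and compound 3 differ by 2-fluorophenyl in place of 4-fluorophenyl on an amide-type nitrogen, with a step that the two limits leave unreadable from compound 2 to compound 3. The evidence so far is the limit of > 25000 nM in this assay, at which 3 of the 3 values shown sit.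

Compound 4 `Cc1cc(NC(=O)Nc2cc(F)ccc2F)c2ccccc2n1` is not yet measured; it differs from compound 3 by fluoro in place of hydrogen on an aromatic carbon. This is the same kind of change as from compound 2 to compound 1, but there the entering fluoro sits ortho to a fluoro group, whereas in compound 4 it sits para to a fluoro group. Because compound 3 gives > 25000 nM, a limit, compound 4 is expected to remain at that limit. For compound 4 the expected step is a step that the limit leaves unreadable from compound 3 to compound 4. The estimate for compound 4 in this assay is 40000 nM, between 20000 nM and 120000 nM.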

Compound 4, half-maximal effective concentration: 12000 nM
For compound 4 the middle estimate is 3.3-fold (0.52 log units) above the measured one; the whole stated range lies above it.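

In this assay, fluoro in place of hydrogen on an aromatic carbon gives an at least 2.0-fold lower number from compound 3 to compound 4 (0.31 log units; beyond the scatter), with the entering fluoro para to a fluoro group. The same kind of change made on compound 2 leads to compound 1, which gives > 25000 nM, a limit. The steps from compound 2 cannot be read; a lower number is shown on the core of compound 3 only, and whether the change carries over to another core is not shown.

From the compounds shown here alone, it remains open whether a chloro, a methoxy or an amine in place of the entering fluoro would give a similar read-out. Also open, going by these compounds, is how a carboxylic acid or a longer chain on the shared core would behave.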